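A carbamate substituent swap in a receptor agonist series

The source may hold more compounds than are shown below. What is called first, only, known or untested is meant among the compounds shown, and "the series" means these compounds.

Compound 1 `CC1(COC(=O)N2CC3COCC(C2)C3Oc2ncnc(Nc3ccc(C#N)cc3Cl)c2F)COC1` carries the highest of the three numbers measured: in a functional assay for agonist activity at Glucose-dependent insulinotropic receptor (Mus musculus), read by cAMP accumulation (a higher number here means that more compound is needed for the effect, a lower number that less compound is needed), compound 1 gives 516 nM. Compound 3 `CC1(OC(=O)N2CC3COCC(C2)C3Oc2ncnc(Nc3ccc(-n4cncn4)cc3F)c2F)CC1` gives 278 nM in this assay, a difference from compound 1 that lies within the scatter, whereas compound 2 `CC1(OC(=O)N2CC3COCC(C2)C3Oc2ncnc(Oc3ccccc3F)c2F)CC1` gives 75 nM, a gap that lies beyond it. Compound 4 `CC1(OC(=O)N2CC3COCC(C2)C3Oc2ncnc(Nc3ccc(C#N)cc3Cl)c2F)CCC1` differs from compound 1 in one place: 1-methylcyclobutyl in place of (3-methyloxetan-3-yl)methyl on an oxygen next to a carbonyl group. Within the data shown here, no measured pair shows this change on its own; compounds 2 and 3 carry another group on the same oxygen and also differ elsewhere, so their values show only that lower numbers are reachable on the shared core. A moderate move toward a lower number is expected, a 2.3-fold lower number from compound 1 to compound 4 (0.37 log units; beyond the scatter). Compound 4 is therefore estimated at 220 nM, with a range from 70 nM to 650 nM.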

Compound 4, half-maximal effective concentration: 60 nM
Compound 4: middle estimate off by 3.7-fold (0.56 log units), on the high side; measured number outside the range, below it.
By their numbers in this assay, from the lowest: compounds 4 and 2 (each within the scatter of the next); then compounds 3 and 1 (each within the scatter of the next).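

Taken on its own, 1-methylcyclobutyl in place of (3-methyloxetan-3-yl)methyl on an oxygen next to a carbonyl group gives, in this assay, an 8.6-fold lower number from compound 1 to compound 4 (0.93 log units; beyond the scatter). With the rest of the molecule unchanged, this shows that the number in this assay responds strongly to the group at this position. No measured evidence on why the step has this size is available.

As far as these compounds go, it remains open whether 3-methyloxetan-3-yl or tert-butyl on the same oxygen would give a number closer to that of compound 1 or compound 4.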